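The compounds below may be only part of what the source reports. "The series", "measured", "known", "first", "only" and "open" are said of these compounds alone.

Measured in a functional assay on NCI-H460 cells (Homo sapiens) for cytotoxicity, read by MTT assay, with a stated time of 72 h; on this read-out lower numbers stand for stronger inhibition and higher numbers for weaker inhibition:
Compound 1 `Cc1[nH]cnc1/C=c1\[nH]c(=O)/c(=C/c2cccc(Oc3ccc(F)cc3)c2)[nH]c1=O`: 47.6 nM
Compound 2 `O=c1[nH]/c(=C\c2nc3ccccc3[nH]2)c(=O)[nH]/c1=C\c1cccc(Oc2ccc(F)cc2)c1`: > 1000 nM (a limit)

Compound 2 stands at > 1000 nM, which is a limit of the assay and not a number. Compound 3 `O=c1[nH]/c(=C\c2cc3ccccc3o2)c(=O)[nH]/c1=C\c1cccc(Oc2ccc(F)cc2)c1` differs from it in one place: 1-benzofuran-2-yl in place of 1H-benzimidazol-2-yl on a double-bonded chain carbon bound to an aromatic carbon. Within the data shown here, the only measured step at this place, an at least 21-fold higher number from compound 1 to compound 2 (1.32 log units; beyond the scatter), is large and beyond the scatter. That step brought in 1H-benzimidazol-2-yl, and the 1-benzofuran-2-yl of compound 3 likewise has one five-membered and one six-membered aromatic ring. No step beyond the scatter is therefore expected in this assay, and the estimated step is a number no higher from compound 2 to compound 3 (the limit leaves the size open). For compound 3 the estimate is 1000 nM, with an expected range of 200 nM to 5000 nM.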

Compound 3, half-maximal inhibitory concentration: 347 nM
The estimate for compound 3 lay 2.9-fold (0.46 log units) above the measured number; low and high end bracket the measured number.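

In this assay, an at least 2.8-fold lower number from compound 2 to compound 3 (0.45 log units; beyond the scatter), so having one five-membered and one six-membered aromatic ring at this place does not alone fix the number at the level of compound 2. Compound 2 itself rests on a limit of the assay, not a number: the limit of > 1000 nM in this assay, at which 1 of the 3 values shown sits. Even so, the 5-methyl-1H-imidazol-4-yl of compound 1 keeps the lowest number of the three, with a 7.3-fold higher number from compound 1 to compound 3 (0.86 log units; beyond the scatter).

Going by these compounds, whether a single ring such as furan-2-yl would come closer to compound 1 remains open. So does the effect of a group carrying an amine at this place.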